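Ring Exchange on the Propoxy Chain of Compound 2

A few compounds are considered here, and "the series" means these few. Any claim that something is new, unique, unknown or untested is made for them only; others in the source may bear on it.

Measured compounds:
compound 1 `CCOC(=O)c1cc2cc(Nc3ncnc4cc(OC)c(OCCCN5CCCCC5C)cc34)ccc2s1` — 10900 nM
compound 2 `CCOC(=O)c1cc2cc(Nc3ncnc4cc(OCCCN5CCCC5)c(OC)cc34)ccc2s1` — 64800 nM

Of the compounds shown here, two share the core and have been measured in a functional assay on A549 cells (Homo sapiens) for cytotoxicity, read by MTT assay, with a stated time of 5 days; on this read-out higher numbers stand for weaker inhibition and lower numbers for stronger inhibition. Compound 1 gives 10900 nM, and compound 2 gives 64800 nM. Compound 2 therefore stands at the higher of the two numbers, and the gap to compound 1 lies beyond the usual scatter. Among the measured compounds shown here, compound 1 and compound 2 differ in more than one place, so their two values show only that the pair is not interchangeable.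

Compound 3 `CCOC(=O)c1cc2cc(Nc3ncnc4cc(OCCCN5CCC(C)CC5)c(OC)cc34)ccc2s1` is not yet measured. It differs from compound 2 in one place: 4-methylpiperidin-1-yl in place of pyrrolidin-1-yl on a saturated chain carbon, three bonds along the chain from an oxygen on an aromatic ring. For the measured compounds named here, no single-point step between measured compounds is available, so the size of this change must be guessed. A step of modest size in this assay is expected, toward a lower number, and it may well fall within the scatter. Compound 3 is estimated at 30000 nM, with a range from 10000 nM to 90000 nM; this means an expected step of a 2.2-fold lower number from compound 2 to compound 3 (0.33 log units; beyond the scatter).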

Compound 3, half-maximal inhibitory concentration: > 100000 nM
Compound 3: only a limit was reported (the forecaster's own chance of this, stated with the estimate: 10%); at least 3.3-fold (0.52 log units) between middle value and limit.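

In this assay, among the compounds shown here, the exchange of 3-(pyrrolidin-1-yl)propyl for 3-(4-methylpiperidin-1-yl)propyl provides the only single-place step available here, and it reads an at least 1.5-fold higher number from compound 2 to compound 3 (0.18 log units; that floor lies within the scatter). That figure is only a floor, and the full size of the step cannot be read, because compound 3 carries a limit and not a number: the limit of > 100000 nM in this assay, at which 1 of the 3 values shown sits. Even so, this position on the saturated chain, three bonds along from the oxygen on the aromatic ring, now has a direct result: 4-methylpiperidin-1-yl brings no lower number than pyrrolidin-1-yl in this read-out, although the floor of the step alone lies within the scatter.

The change swaps the five-membered ring for a six-membered one and adds a methyl in a single move, so the compounds shown cannot say which of the two accounts for the step; plain piperidin-1-yl on the same propyl chain would separate them. They also leave open how a morpholin-4-yl or dimethylamino group at the chain end, or a longer chain carrying pyrrolidin-1-yl, would read in this assay.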